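From sulfur to oxygen: expected stability of compound 4

A few compounds are considered here, and "the series" means these few. Any claim that something is new, unique, unknown or untested is made for them only; others in the source may bear on it.

compound 1 `O=C(NCc1ccc(S(=O)(=O)N2CCCCC2)cc1)c1cc2cnccc2o1` gives 4.6%
compound 2 `O=C(NCc1ccc(S(=O)(=O)N2CCCCC2)cc1)c1cnc2nccn2c1` gives 0.28%
compound 3 `O=C(NCc1ccc(S(=O)(=O)N2CCCCC2)cc1)c1cc2cccnc2s1` gives "below limit of detection" (no number reported)

All three results come from an ADME assay on microsomes from liver (Mus musculus) for metabolic stability, read by LC-MS, with a stated time of 30 min, tested at 1 uM (a higher number here means that more of the compound is left, a lower number that less of the compound is left), and describe how much of each compound survives exposure to liver microsomes. Compound 3 stands at "below limit of detection" (no number reported) in this test, and that gives no single number for it. For the measured compounds named here, no size of step can therefore be worked out from compound 3.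

The next compound is compound 4 `O=C(NCc1ccc(S(=O)(=O)N2CCCCC2)cc1)c1cc2ccncc2o1`, and the structural change is a group of 9 heavy atoms (7 carbon, 1 nitrogen, 1 oxygen; one five-membered aromatic ring with 1 hetero atom, one six-membered aromatic ring with 1 hetero atom) in place of a group of 9 heavy atoms (7 carbon, 1 nitrogen, 1 sulfur; one five-membered aromatic ring with 1 hetero atom, one six-membered aromatic ring with 1 hetero atom), on a carbonyl carbon on a carbonyl carbon. Going by the values given here, the one measured step that bears on this is a number 4.3 percentage points lower from compound 1 to compound 2 (within the scatter), a similar exchange of groups at that carbonyl carbon. The group entering compound 4 has the same atom make-up as the group in compound 1 , which gives 4.6% in this assay. On this evidence, no step beyond the scatter is expected, and little of compound 4 should remain. The expected value for compound 4 is 3%, with an estimated range of 0.4% to 12%.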

Compound 4, percent of the compound remaining: 0.14%
Compound 4: middle estimate off by 2.9 percentage points, on the high side, outside the stated range (below it).
By their numbers in this assay, from the lowest: compounds 4, 2 and 1 (each within the scatter of the next).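

In this assay, compound 4 carries a group with the same atom make-up as the group in compound 1, arranged differently, and this exchange gives a number 4.5 percentage points lower from compound 1 to compound 4 (within the scatter). For the compounds shown here, exchanging the group with three nitrogens for the one in compound 4 gives a number 0.1 percentage points lower from compound 2 to compound 4 (within the scatter), so neither the arrangement of these atoms nor this change of atoms moves the result beyond the scatter. Steps involving compound 3 cannot be read, as it has no number, and no measurement shown here explains how little of these compounds remains.

Open, going by these compounds, is whether any group on this carbonyl carbon can leave clearly more compound intact, since only groups made of a five-membered and a six-membered aromatic ring appear here. A single phenyl ring or a short alkyl chain in that place would test this.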